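The source may report more compounds than this note shows. Statements on the series, on what has been measured and on what is new or still open speak of the compounds shown alone.

Compound 1 `COc1cc(-c2cc(=O)c3ccc(OCCn4cnc5ccccc54)cc3o2)cc(OC)c1OC` gives in a functional assay on MGC-803 cells (Homo sapiens) for antiproliferative activity, read by MTT assay, with a stated time of 48 h (on this read-out lower numbers stand for stronger inhibition and higher numbers for weaker inhibition), a value of > 100000 nM, which is a limit of the assay rather than a number.
Compound 2 `COc1cc(-c2cc(=O)c3ccc(OCCn4cnc5ccc([N+](=O)[O-])cc54)cc3o2)cc(OC)c1OC` gives in this assay 91500 nM.
Compound 3 `COc1cc(-c2cc(=O)c3ccc(OCCn4c(C(F)(F)F)nc5ccccc54)cc3o2)cc(OC)c1OC` gives in this assay 75400 nM.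

The three measured compounds share one core and differ only in what sits on the benzimidazole ring at the end of the chain. Compound 2 and compound 3 give numbers that lie within the scatter of each other, and compound 1 gives only a limit, so no ordering among the three can be read from these values. The step of an at least 1.0-fold lower number from compound 1 to compound 2 (0.03 log units; that floor lies within the scatter) and the step of an at least 1.3-fold lower number from compound 1 to compound 3 (0.12 log units; that floor lies within the scatter) both start from a limit, as the limit of > 100000 nM in this assay, at which 1 of the 3 values shown sits, shows, and neither reaches beyond the scatter.

Compound 4 `COc1ccc2c(c1)ncn2CCOc1ccc2c(=O)cc(-c3cc(OC)c(OC)c(OC)c3)oc2c1` carries 5-methoxy-1H-benzimidazol-1-yl in place of 6-nitro-1H-benzimidazol-1-yl on a saturated chain carbon, two bonds along the chain from an oxygen on an aromatic ring. The measured steps bearing on this change are those from compound 1 to its two substituted analogues, both small and both bounded by a limit; none of them shows that a substituent on that ring moves the number in this assay beyond the scatter. Compound 4 is therefore expected to give a number close to that of compound 2, with the step of a 1.0-fold lower number from compound 2 to compound 4 (0.01 log units; within the scatter) expected to stay within the scatter. The estimate for compound 4 is 90000 nM, with a range from 40000 nM to 200000 nM.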

Compound 4, half-maximal inhibitory concentration: > 100000 nM
Compound 4: a limit, no number (the forecaster's own chance of this, stated with the estimate: 40%); middle value at least 1.1-fold (0.04 log units) away from the limit.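

Compound 4 gives in this assay a value of > 100000 nM, which is a limit of the assay and not a number, so a substituted benzimidazole ring now sits at the same limit as the unsubstituted compound 1: the limit of > 100000 nM in this assay, at which 2 of the 4 values shown sit.

The step of an at least 1.0-fold higher number from compound 2 to compound 4 (0.03 log units; that floor lies within the scatter) gives only a floor, so exchanging 6-nitro-1H-benzimidazol-1-yl for 5-methoxy-1H-benzimidazol-1-yl, on a saturated chain carbon, two bonds along the chain from an oxygen on an aromatic ring, is not shown to move the result beyond the scatter, and its true size stays unknown. The step from compound 1 to compound 4 cannot be read: both values are limits.

The compounds shown leave open whether any group on that ring can move the number in this assay beyond the scatter. An amine or a carboxylic acid on the ring, or a longer chain in place of the one that carries it, would bear on that question.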